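A few compounds are considered here, and "the series" means these few. Any claim that something is new, unique, unknown or untested is made for them only; others in the source may bear on it.

Compound 1 `COC(=O)Nc1c(N)nc(-c2nn(Cc3ccccc3F)c3ncccc23)nc1N`, in an assay on cells for activation of Guanylate cyclase soluble subunit alpha-1 (Rattus norvegicus), read by cGMP accumulation and immunoassay, with a stated time of 10 min; on this read-out higher numbers stand for an effect only at larger amounts of compound and lower numbers for an effect already at smaller amounts: 0.3 uM.
Compound 2 `CC(C)OC(=O)Nc1c(N)nc(-c2nn(Cc3ccccc3F)c3ncccc23)nc1N`, in this assay: 0.8 uM.

Going by the values given here, of the two numbers so far, compound 2 has the higher one; the single measured step, a 2.7-fold higher number from compound 1 to compound 2 (0.43 log units; beyond the scatter), was a modest move toward higher numbers when the group on the oxygen grew. Compound 3 `Nc1nc(-c2nn(Cc3ccccc3F)c3ncccc23)nc(N)c1NC(=O)OCC1CC1` differs from compound 2 in one place: cyclopropylmethyl in place of isopropyl on an oxygen next to a carbonyl group. Among the compounds with values here, only that one step bears on this change, and it offers a weak guide. For compound 3 the expected step is a 1.3-fold higher number from compound 2 to compound 3 (0.10 log units; within the scatter), likely within the scatter. Compound 3 is therefore estimated at 1 uM, with a range from 0.4 uM to 3 uM.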

Compound 3, minimum effective concentration: 0.2 uM
Compound 3: the middle estimate sits 5.0-fold (0.70 log units) above what was measured; measured number outside the range, below it.
By their numbers in this assay, from the lowest: compounds 3 and 1 (each within the scatter of the next); then compound 2.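

The number in this assay does not simply climb as the group on this oxygen grows: cyclopropylmethyl in place of isopropyl brings a 4.0-fold lower number from compound 2 to compound 3 (0.60 log units; beyond the scatter) and so reverses the earlier rise. Cyclopropyl in place of hydrogen on the saturated chain carbon bound to that oxygen gives a 1.5-fold lower number from compound 1 to compound 3 (0.18 log units; within the scatter) and thus no readable change. Nothing given here explains why these two groups differ. Going by these compounds, it stays open whether the three-membered ring itself matters, and how an open chain such as n-butyl or a larger ring as in cyclobutylmethyl would read on this oxygen.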